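Swapping fluoro for trifluoromethoxy on a weak inhibitor

The source may hold more compounds than are shown below. What is called first, only, known or untested is meant among the compounds shown, and "the series" means these compounds.

Compound 1 `Oc1cccc(-c2cc(-c3ccccc3F)cc(-c3ccccc3O)n2)c1` gives 24200 nM in a functional assay on T47D cells (Homo sapiens) for inhibition (a lower number here means a stronger inhibitor, a higher number a weaker inhibitor), the highest of the two numbers recorded so far. Going by the values given here, its only measured neighbour, compound 2 `Oc1ccc(-c2cc(-c3ccccc3F)cc(-c3cccc(O)c3)n2)cc1`, shows 6370 nM; that step a 3.8-fold lower number from compound 1 to compound 2 (0.58 log units; beyond the scatter) reflects 4-hydroxyphenyl in place of 2-hydroxyphenyl on an aromatic carbon and concerns a different part of the molecule. Compound 3 `Oc1cccc(-c2cc(-c3ccccc3OC(F)(F)F)cc(-c3ccccc3O)n2)c1` departs from compound 1 by trifluoromethoxy in place of fluoro on an aromatic carbon. Among the compounds with values here, no measured pair in this set bears on that change: the single step on record touches the hydroxyphenyl ring, not the group on the fluorinated ring. Without any precedent, the expected step in this assay a 1.2-fold lower number from compound 1 to compound 3 (0.08 log units; within the scatter) is treated as none beyond the scatter, with wide uncertainty. Compound 3 is therefore estimated at 20000 nM, with a plausible range from 6000 nM to 60000 nM.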

Compound 3, half-maximal inhibitory concentration: 2680 nM
Estimate against measurement, compound 3: 7.5-fold (0.87 log units) above; the measured number lies below the stated range.
By their numbers in this assay, from the lowest: compound 3; then compound 2; then compound 1.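

In this assay, the position ortho to a large group proves sensitive to what it carries: trifluoromethoxy in place of fluoro gives a 9.0-fold lower number from compound 1 to compound 3 (0.96 log units; beyond the scatter). The earlier compounds shown here showed movement only through the hydroxyphenyl ring, so compound 3 establishes a second place on the core of compound 1 where a single change shifts the number beyond the scatter. Nothing available explains this drop.

The compounds shown leave open whether the shift is particular to trifluoromethoxy or would also appear with other groups here, such as methoxy, trifluoromethyl or an amine. They also leave open whether the 4-hydroxyphenyl change seen in compound 2 and the trifluoromethoxy change seen in compound 3 would add up within one molecule.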